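The source may report more compounds than this note shows. Statements on the series, on what has been measured and on what is new or still open speak of the compounds shown alone.

Compounds measured so far in an ADME assay on microsomes from liver (Canis lupus familiaris) for metabolic stability; a lower number here means that the compound disappears faster, a higher number that the compound lasts longer:

Compound 1, `N#Cc1ccc(NCCNc2ncc(-c3ncc[nH]3)c(-c3ccc(Cl)cc3Cl)n2)nc1`; in this assay compound 1 gives > 0.5 h, which is a limit of the assay rather than a number.
Compound 2, `Nc1nc(NCCNc2ncc(-c3ncc[nH]3)c(-c3cc(F)c(F)cc3F)n2)ccc1[N+](=O)[O-]`; in this assay compound 2 gives > 0.5 h, again a limit.
Compound 3, `Nc1nc(NCCNc2ncc(-c3ncc[nH]3)c(-c3ccc(F)cc3Cl)n2)ccc1[N+](=O)[O-]`; in this assay compound 3 gives > 0.5 h, also a limit.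

Compound 3 therefore stands where every measured value here stands: at the limit of > 0.5 h in this assay, at which 3 of the 3 values shown sit, with no number of its own to set it apart. Among the compounds with values here, the one step between neighbours, a step that the two limits leave unreadable from compound 2 to compound 3, cannot be sized, since both ends are limits.

Compound 4, `COc1cc(Cl)ccc1-c1nc(NCCNc2ccc([N+](=O)[O-])c(N)n2)ncc1-c1ncc[nH]1`, has not yet been measured in this assay. It differs from compound 3 by 4-chloro-2-methoxyphenyl in place of 2-chloro-4-fluorophenyl on an aromatic carbon.

Within the data shown here, no measured step bears readably on this change; the only neighbouring step is the unreadable one from compound 2 to compound 3. The three measured values all sit at the same limit, so compound 4 is expected to sit there too, with no step beyond the scatter: the estimated step that the limit leaves unreadable from compound 3 to compound 4 reflects this. For compound 4 the estimated half-life in this assay is 0.8 h, within a range from 0.4 h to 1.6 h.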

Compound 4, half-life: > 0.5 h
Compound 4 ended at the assay's limit (the forecaster's own chance of this, stated with the estimate: 85%); the middle value is on the limit's open side.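

Compound 4 gives > 0.5 h in this assay, which is a limit of the assay. Within the data shown here, no step from compound 2 or compound 3 to compound 4 can be read: the limit of > 0.5 h in this assay, at which 4 of the 4 values shown sit. The compounds shown leave open how long each half-life actually is and whether the exchanged groups change it.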